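This account rests on a few compounds, and the source may have more. Where it says the series, first, only, none or still open, it means among the compounds named here.

Measured compounds and their values:

- Compound 1, `COc1ccc(C(=O)c2ccc3c(c2)C=CC(C)(C)O3)c(NC(=O)CO)c1`: 250 nM
- Compound 2, `COc1ccc(C(=O)c2ccc3c(c2)C=CC(C)(C)O3)c(NC(=O)CN)c1`: 490 nM
- Compound 3, `C=C(c1ccc(OC)cc1NC(=O)CO)c1ccc(OC)c2c1C=CC(C)(C)O2`: 470 nM

All three were tested in a functional assay on HCT-8 cells (Homo sapiens) for antiproliferative activity, read by MTT assay, with a stated time of 48 h; on this read-out lower numbers stand for stronger inhibition and higher numbers for weaker inhibition. Compound 1 gives 250 nM, compound 2 gives 490 nM, and compound 3 gives 470 nM. Compound 1 and compound 2 differ in one place: amino in place of hydroxy on a saturated chain carbon bound to a carbonyl carbon. That change made a 2.0-fold higher number from compound 1 to compound 2 (0.29 log units; within the scatter), so the two compounds cannot be told apart on this read-out. Compound 3 carries a different core, and the difference between its core and that of compound 1 is not broken down here; the values of compound 1 and compound 3 lie within the scatter of each other, as do those of compound 2 and compound 3.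

Compound 4, `C=C(c1ccc(OC)cc1NC(=O)CN)c1ccc(OC)c2c1C=CC(C)(C)O2`, has not yet been measured in this assay. It differs from compound 3 in one place: amino in place of hydroxy on a saturated chain carbon bound to a carbonyl carbon. Among the compounds with values here, this is the same change as the one from compound 1 to compound 2, made on the same kind of carbon, only on the core of compound 3. For compound 4 the expectation is a step of a 1.9-fold higher number from compound 3 to compound 4 (0.28 log units; within the scatter), a size that rests on the earlier step of a 2.0-fold higher number from compound 1 to compound 2 (0.29 log units; within the scatter) measured on the other core. On that basis compound 4 is estimated at 900 nM in this assay, with an expected range from 400 nM to 2000 nM.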

Compound 4, half-maximal inhibitory concentration: 520 nM
Compound 4: the middle estimate sits 1.7-fold (0.24 log units) above what was measured; the range from low to high includes it.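

In this assay, putting amino in place of hydroxy on a saturated chain carbon bound to a carbonyl carbon gives a 1.1-fold higher number from compound 3 to compound 4 (0.04 log units; within the scatter) and so leaves compound 3 and compound 4 indistinguishable on this read-out. Set beside the same change on the core of compound 1, the step on the core of compound 3 shows that this swap carries over between these two cores without a detectable difference in size: the same change on two cores in this assay, a 2.0-fold higher number (0.29 log units; within the scatter) from compound 1 to compound 2 and a 1.1-fold higher number (0.04 log units; within the scatter) from compound 3 to compound 4, 1.8-fold (0.25 log units) apart, within the scatter of two such steps

Within the data shown here, this does not show that the swap is without any effect, since steps this small cannot be separated from the ordinary spread of repeated measurements, and it does not show that the step would stay the same on a third core, as the comparison rests on only two pairs of compounds in a single cell assay.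

The compounds shown leave open whether a group that differs more from hydroxy and amino, such as a dimethylamino group or a carboxylic acid, would produce a step large enough to read on either core. They also leave open what a longer chain carrying the hydroxy or amino group would do, and whether two cores would then still respond alike.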